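Cytotoxicity Outlook for a Pyridylmethyl Analogue of Compound 1

The compounds below may be only part of what the source reports. "The series", "measured", "known", "first", "only" and "open" are said of these compounds alone.

The series is followed in an ADME assay on MRC5 cells (Homo sapiens) for inhibition, with a stated time of 72 h (a higher number here means that more compound is needed for the effect, a lower number that less compound is needed), where two compounds carry numbers. Compound 1 `COc1cccc(OC)c1C(=O)Nc1c[nH]nc1C(=O)NC1CCCCCC1` gives 42000 nM, the highest of the two values recorded. Compound 2 `CO[C@H]1CC[C@H](NC(=O)c2n[nH]cc2NC(=O)c2cc3ccccc3o2)CC1` gives 800 nM, a far lower number that lies beyond the scatter of the method; the two structures differ in several places, so no single change can be tied to that gap.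

Compound 3 `COc1cccc(OC)c1C(=O)Nc1c[nH]nc1C(=O)NCc1ccccn1` is not yet measured. Relative to compound 1 it carries (pyridin-2-yl)methyl in place of cycloheptyl on an amide-type nitrogen. Going by the values given here, no step between measured compounds of this kind is available, so the expectation rests on the value of compound 1 alone. Compound 3 is expected to stay near compound 1, with a step of a 1.2-fold higher number from compound 1 to compound 3 (0.08 log units; within the scatter) that is modest, if any, beyond the scatter. The estimate for compound 3 in this assay is 50000 nM, within 15000 nM to 150000 nM.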

Compound 3, half-maximal effective concentration: > 50000 nM
Compound 3: only a limit was reported (the forecaster's own chance of this, stated with the estimate: 30%); the middle value lies on the limit itself.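

In this assay compound 3 gives only a limit, > 50000 nM, and not a number. Placing (pyridin-2-yl)methyl in place of cycloheptyl on the amide-type nitrogen gives an at least 1.1-fold higher number from compound 1 to compound 3 (0.07 log units; that floor lies within the scatter), so this first step at this position brings no lower number, even though a carbon-only seven-membered ring gives way to a six-membered aromatic ring with a hetero atom. The step is bounded on one side only: the limit of > 50000 nM in this assay, at which 1 of the 3 values shown sits.

Going by these compounds, how a benzyl group or a cyclohexyl group would read on this nitrogen remains open, so the part of the ring nitrogen in (pyridin-2-yl)methyl cannot be separated from that of the ring itself. On these data alone, it also stays open how far the true number of compound 3 lies past its limit.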